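Trading a fluorobenzyl arm for an aminoethyl arm

The source may hold more compounds than are shown below. What is called first, only, known or untested is meant among the compounds shown, and "the series" means these compounds.

Compound 2 `O=C(NCc1ccc(F)cc1)c1nc(Br)c2cccnc2c1NCc1ccc(F)cc1` is a close relative of compound 1 `O=C(NCc1ccc(F)cc1)c1nc(Br)c2cccnc2c1NCCCNc1c(C(=O)NCc2ccc(F)cc2)nc(Br)c2cccnc12`. In a functional assay on HCT-116 cells (Homo sapiens) for cytotoxicity, read by MTT assay, with a stated time of 72 h (a lower number here means a stronger inhibitor, a higher number a weaker inhibitor), compound 1 gives no number, only the limit of the assay, > 20000 nM. Compound 2 likewise gives only a limit in this assay, > 20000 nM. So compound 2 stands, with the one other measured compound, at the edge of what the assay can report, (the limit of > 20000 nM in this assay, at which 2 of the 2 values shown sit). Compound 3 `NCCNc1c(C(=O)NCc2ccc(F)cc2)nc(Br)c2cccnc12` differs from compound 2 in one place: aminomethyl in place of 4-fluorophenyl on a saturated chain carbon bound to a nitrogen on an aromatic ring. Going by the values given here, with no measured step to lean on, the change is expected to amount to a step that the limit leaves unreadable from compound 2 to compound 3, nothing beyond the scatter. Compound 3 is therefore expected to give about 30000 nM in this assay, within 10000 nM to 100000 nM, most likely again reported only as a limit.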

Compound 3, half-maximal inhibitory concentration: > 20000 nM
Compound 3 was reported as a limit; the forecaster's own chance of this, stated with the estimate: 80%; the middle value lies beyond the limit too.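

Going by these compounds alone, compound 2 and compound 3 are both reported only as limits, so no step between them can be read: the limit of > 20000 nM in this assay, at which 3 of the 3 values shown sit. The compounds shown leave open how the 4-fluorobenzyl and 2-aminoethyl arms truly compare in this assay.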